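The source may hold more compounds than are shown below. What is called first, only, known or untested is meant among the compounds shown, and "the series" means these compounds.

In an in vitro functional assay on cells for agonist activity at Bombesin receptor subtype-3 (Homo sapiens), read by luminescence and calcium flux (on this read-out lower numbers stand for an effect already at smaller amounts and higher numbers for an effect only at larger amounts of compound), three compounds have been measured. Among the compounds with values here, compound 1 `CCCCc1cnc(C(CCCO)Cc2ccc(-c3ccccc3C(=O)O)cc2)[nH]1` gives 1900 nM, and compound 2 `CCCCc1cnc(C(CCCC)Cc2ccc(-c3ccccc3C(=O)O)cc2)[nH]1` gives 2660 nM; the one change between them, methyl in place of hydroxy on a saturated chain carbon, four bonds along the chain from an aromatic carbon, brings a 1.4-fold higher number from compound 1 to compound 2 (0.15 log units; within the scatter). Compound 3 `O=C(O)c1ccccc1-c1ccc(CCc2ncc(-c3ccccc3)[nH]2)cc1` gives 4950 nM, the highest of the three numbers, though its gap to compound 2 lies within the scatter while its gap to compound 1 lies beyond it.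

The step to compound 4 `CC(C)(C)c1cnc(CCc2ccc(-c3ccccc3C(=O)O)cc2)[nH]1` alters the five-membered aromatic ring with 2 nitrogen: tert-butyl in place of phenyl on an aromatic carbon. Within the data shown here, no measured step matches this change; the single measured step concerns a saturated chain elsewhere on the shared core, so it offers no direct guide. What the data do show is that compound 1 and compound 2, which lack the phenyl of compound 3 on the shared core, give lower numbers than compound 3, one of them beyond the scatter. A tert-butyl, a group with no ring, is therefore expected to land near those numbers or near compound 3, and the expected step is a 1.7-fold lower number from compound 3 to compound 4 (0.22 log units; within the scatter). Compound 4 is estimated at 3000 nM, with a range from 1000 nM to 9000 nM.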

Compound 4, half-maximal effective concentration: 4330 nM
Compound 4: the middle estimate sits 1.4-fold (0.16 log units) below what was measured, and the stated range covers the measured number.
By their numbers in this assay, from the lowest: compounds 1, 2, 4 and 3 (each within the scatter of the next, the first and the last beyond it).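

Within the data shown here, the swap of phenyl for tert-butyl brings a 1.1-fold lower number from compound 3 to compound 4 (0.06 log units; within the scatter) in this assay and gives the first reading at this place on the shared core, an aromatic carbon of the five-membered aromatic ring with 2 nitrogen. Here, a group with no ring and 4 heavy atoms cannot be told apart from a six-membered aromatic ring of carbon with 6 heavy atoms, so within this pair the aromatic ring at this carbon is not needed to keep the number in this range. No measurement at hand accounts for this result.

Going by these compounds, this single pair says nothing about how far the position can be pushed, and whether a methyl or an amine on this carbon would also read alike remains open. Compound 1 and compound 2 also differ from compound 4 in the saturated chain, so they cannot show what their own group at this carbon does on its own.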